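The source may hold more compounds than are shown below. What is called first, only, known or untested is meant among the compounds shown, and "the series" means these compounds.

In a functional assay on HepG2 cells (Homo sapiens) for inhibition, read by MTT assay (on this read-out lower numbers stand for stronger inhibition and higher numbers for weaker inhibition), three amides built on one shared core differ only in the methylphenyl group on a carbonyl carbon. Compound 1 (`COc1cc2ncnc(Nc3ccc(NC(=O)c4ccccc4C)cc3)c2cc1OC`), with 2-methylphenyl, gives 15000 nM. Compound 2 (`COc1cc2ncnc(Nc3ccc(NC(=O)c4cccc(C)c4)cc3)c2cc1OC`), with 3-methylphenyl, gives 7500 nM. Compound 3 (`COc1cc2ncnc(Nc3ccc(NC(=O)c4ccc(C)cc4)cc3)c2cc1OC`), with 4-methylphenyl, gives 25000 nM. Two measured steps place this last value: a 1.7-fold higher number from compound 1 to compound 3 (0.22 log units; within the scatter) is small, while a 3.3-fold higher number from compound 2 to compound 3 (0.52 log units; beyond the scatter) is modest. Compound 3 therefore shares the upper end of the range with compound 1.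

Compound 4 (`COc1cc2ncnc(Nc3ccc(NC(=O)c4ccccc4OC)cc3)c2cc1OC`) has not yet been measured. Its difference from compound 3 is 2-methoxyphenyl in place of 4-methylphenyl on a carbonyl carbon. Going by the values given here, no measured step exchanges a methylphenyl for a methoxyphenyl, so the evidence is indirect. The closest comparison is compound 1, the 2-methylphenyl amide, at 15000 nM. The largest step among the three methylphenyl amides is only a 3.3-fold higher number from compound 2 to compound 3 (0.52 log units; beyond the scatter). A small fall in the number is thus expected in this assay, with no change beyond the scatter. The estimated step is a 1.7-fold lower number from compound 3 to compound 4 (0.22 log units; within the scatter). For compound 4 the expected value is 15000 nM, with an estimated range from 6000 nM to 35000 nM.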

Compound 4, half-maximal inhibitory concentration: > 100000 nM
Compound 4: only a limit was reported; the forecaster's own chance of this, stated with the estimate: 5%; middle value at least 6.6-fold (0.82 log units) away from the limit.
By their numbers in this assay, from the lowest: compounds 2, 1 and 3 (each within the scatter of the next, the first and the last beyond it). At a limit, above all of these: compound 4.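

Compound 4 gives a limit of the assay and not a number: the limit of > 100000 nM in this assay, at which 1 of the 4 values shown sits. At this position, methoxy in place of methyl on an aromatic carbon gives an at least 6.6-fold higher number from compound 1 to compound 4 (0.82 log units; beyond the scatter), a larger shift than the largest one seen when only the place of the methyl differed, a 3.3-fold higher number from compound 2 to compound 3 (0.52 log units; beyond the scatter), so the identity of the group here had a greater effect on the number in this assay than any of the earlier exchanges. The other two comparisons point the same way, with an at least 4.0-fold higher number from compound 3 to compound 4 (0.60 log units; beyond the scatter) and an at least 13-fold higher number from compound 2 to compound 4 (1.12 log units; beyond the scatter), which makes the 2-methoxyphenyl amide the weakest of the four compounds in this assay, while a single added oxygen separates it from compound 1.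

The compounds shown leave open what the actual number for compound 4 would be, so the full size of these steps stays unknown. They also leave open whether the shift belongs to methoxy alone or would also follow from hydroxy, ethoxy or chlorine on the same aromatic carbon.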